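Hydroxy in place of fluoro: compound 4 expected

The compounds below may be only part of what the source reports. "The series", "measured", "known", "first", "only" and "open" are said of these compounds alone.

The series shares one core, varied at the distal aryl ring and at the chain terminus. Compound 1 `CN(Cc1ccc(OCCCNC(=N)N)cc1)c1nc2ccc(Oc3ccc(C(F)(F)F)cc3)cc2s1` gives 185000 nM in an assay on SH-SY5Y cells for inhibition of Voltage-dependent N-type calcium channel subunit alpha-1B (Homo sapiens), read by FLIPR and calcium flux, with stated times of 600 s and 300 s, in the presence of a further agent that is not named here; on this read-out lower numbers stand for stronger inhibition and higher numbers for weaker inhibition. Compound 2 `CN(Cc1ccc(OCCCNC(=N)N)cc1)c1nc2ccc(Oc3ccc(F)cc3)cc2s1` gives 100000 nM in this assay, and compound 3 `CN(Cc1ccc(OCCCN)cc1)c1nc2ccc(Oc3ccc(F)cc3)cc2s1` gives 98000 nM in this assay. Both measured steps are small: a 1.9-fold lower number from compound 1 to compound 2 (0.27 log units; within the scatter), and a 1.0-fold lower number from compound 2 to compound 3 (0.01 log units; within the scatter). On the numbers shown, compound 2 sits within the scatter of both others, nearest to compound 3 and furthest from compound 1, so no member of the trio can be set apart.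

Compound 4 `CN(Cc1ccc(OCCCNC(=N)N)cc1)c1nc2ccc(Oc3ccc(O)cc3)cc2s1` is not yet measured. Relative to compound 2 the change is hydroxy in place of fluoro on an aromatic carbon, read one bond further out as 4-fluorophenoxy to 4-hydroxyphenoxy. The step that bears on it is the earlier exchange at the same aromatic carbon, fluoro for trifluoromethyl, which gave a 1.9-fold lower number from compound 1 to compound 2 (0.27 log units; within the scatter); the chain-terminus step a 1.0-fold lower number from compound 2 to compound 3 (0.01 log units; within the scatter) concerns another part of the molecule. Two substituents at this carbon have left the number unmoved beyond the scatter, and nothing here argues that hydroxy should behave otherwise.

Compound 4 is therefore expected at 100000 nM in this assay, with a range from 40000 nM to 250000 nM. The expected step is no change at the digits printed from compound 2 to compound 4 (within the scatter), that is none beyond the scatter.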

Compound 4, half-maximal inhibitory concentration: 432000 nM
Compound 4: the middle estimate sits 4.3-fold (0.64 log units) below what was measured; measured number above the stated range.
By their numbers in this assay, from the lowest: compounds 3, 2 and 1 (each within the scatter of the next); then compound 4.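

In this assay, for the compounds shown here, the substituent on this aromatic carbon now matters: hydroxy gives a 4.3-fold higher number from compound 2 to compound 4 (0.64 log units; beyond the scatter) and also a 2.3-fold higher number from compound 1 to compound 4 (0.37 log units; beyond the scatter), the only steps so far that lie beyond the scatter. Fluoro and trifluoromethyl stay within the scatter of each other here, so among the three substituents only hydroxy sets its compound apart, and it does so towards weaker inhibition, with a modest step from either partner. Hydroxy brings a hydrogen-bond donor and a hydrogen-bond acceptor where fluoro counts neither, but the data offer no measurement that would explain the higher number.

From the compounds shown here alone, whether the step follows the hydroxy group itself or any oxygen or nitrogen substituent at this carbon stays open, and a methoxy group or an amine in the same place would separate these readings. Also open is whether the same step appears with the amine terminus of compound 3, since that terminus is shown only with the 4-fluorophenoxy group, and whether a longer chain would change either result.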